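Working notes: ethoxycarbonyl on compound 3

A few compounds are considered here, and "the series" means these few. Any claim that something is new, unique, unknown or untested is made for them only; others in the source may bear on it.

In an ADME assay on MT4 cells (Homo sapiens) for cytotoxicity (on this read-out lower numbers stand for higher toxicity in this test and higher numbers for lower toxicity in this test), compound 3 (`FC(F)(F)c1cccc(NC(=S)Nc2ccccc2)c1`) stands highest of the three measured compounds at 39000 nM with hydrogen at the position under study. Compound 1 (`O=[N+]([O-])c1ccc(NC(=S)Nc2cccc(C(F)(F)F)c2)cc1`) gives 9200 nM with nitro there, and compound 2 (`N#Cc1ccc(NC(=S)Nc2cccc(C(F)(F)F)c2)cc1`) gives 7000 nM with cyano there.

Compound 4 (`CCOC(=O)c1ccc(NC(=S)Nc2cccc(C(F)(F)F)c2)cc1`) derives from compound 3 with ethoxycarbonyl in place of hydrogen on an aromatic carbon, para to a large group (ethoxycarbonyl in place of hydrogen on an aromatic carbon).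

The nearest evidence runs in the reverse direction. Hydrogen in place of nitro gives a 4.2-fold higher number from compound 1 to compound 3 (0.63 log units; beyond the scatter) in this read-out, and hydrogen in place of cyano gives a 5.6-fold higher number from compound 2 to compound 3 (0.75 log units; beyond the scatter) in the same read-out. Both steps are modest and beyond the scatter. Cyano in place of nitro gives a 1.3-fold lower number from compound 1 to compound 2 (0.12 log units; within the scatter) and so does not separate those two groups. Neither group is ethoxycarbonyl, and only these two substituted compounds support the reading, so the transfer is tentative. None of the three compounds goes against it.

A modest step to a lower number in this assay is therefore expected, similar in size to the two reverse steps. The expected step is a 3.9-fold lower number from compound 3 to compound 4 (0.59 log units; beyond the scatter) by this estimate. Compound 4 is expected at 10000 nM (estimated range 4000 nM to 30000 nM).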

Compound 4, half-maximal cytotoxic concentration: 23000 nM
The estimate for compound 4 lay 2.3-fold (0.36 log units) below the measured number; measured number inside the range.
By their numbers in this assay, from the lowest: compounds 2 and 1 (each within the scatter of the next); then compounds 4 and 3 (each within the scatter of the next).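

Working notes, continued: in this assay, a substituent at this position does not by itself separate a compound from the unsubstituted one. Ethoxycarbonyl gives a 1.7-fold lower number from compound 3 to compound 4 (0.23 log units; within the scatter), so compound 4 is the first substituted compound shown that stays within the scatter of compound 3, whereas nitro and cyano both fell beyond it. The position therefore distinguishes among substituents: the change to ethoxycarbonyl gives a 3.3-fold higher number from compound 2 to compound 4 (0.52 log units; beyond the scatter) and a 2.5-fold higher number from compound 1 to compound 4 (0.40 log units; beyond the scatter), both modest steps beyond the scatter, which the earlier pair, with nitro and cyano inseparable, could not show. No supporting measurement accounts for this difference between ethoxycarbonyl and the other two groups.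

Only three substituents at this position are shown, so it remains open where a carboxylic acid, an amine or a longer chain in place of ethoxycarbonyl would fall relative to compound 3. On these data alone, it also remains open whether ethoxycarbonyl would behave the same way on an aromatic carbon that is not para to a large group, or on a core other than the one shared by these four compounds.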